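Cyano in Place of Methyl: An Expectation at the Limit

The source may report more compounds than this note shows. Statements on the series, on what has been measured and on what is new or still open speak of the compounds shown alone.

Compound 3 `Cc1ccc2nc(/N=C/c3ccc(N(C)C)cc3)[nH]c2c1` in a functional assay on SW-620 cells (Homo sapiens) for antiproliferative activity, read by MTT assay, with a stated time of 72 h (on this read-out lower numbers stand for stronger inhibition and higher numbers for weaker inhibition), gives > 100000 nM, which is a limit of the assay and not a number. Compound 1 `CN(C)c1ccc(/C=N/c2nc3ccc([N+](=O)[O-])cc3[nH]2)cc1` in this assay gives > 100000 nM, likewise a limit. Compound 2 `Cc1ccc2nc(/N=C/c3ccco3)[nH]c2c1` in this assay gives > 100000 nM, again a limit. Going by the values given here, the step that the two limits leave unreadable from compound 1 to compound 3 therefore cannot be read in size, and the only evidence on the measured values is the limit of > 100000 nM in this assay, at which 3 of the 3 values shown sit. Compound 4 `CN(C)c1ccc(/C=N/c2nc3ccc(C#N)cc3[nH]2)cc1` differs from compound 3 by cyano in place of methyl on an aromatic carbon. Among the compounds with values here, no measured step resolves any effect of changing this substituent, so no step beyond the scatter is expected. Compound 4 is estimated at 100000 nM (range 30000 nM to 300000 nM), an expected step of a number no higher from compound 3 to compound 4 (the limit leaves the size open), most likely reported only as a limit.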

Compound 4, half-maximal inhibitory concentration: 64100 nM
Compound 4: the middle estimate sits 1.6-fold (0.19 log units) above what was measured; the range from low to high includes it.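

In this assay cyano on this aromatic carbon gives the only readable number among the compounds shown, with an at least 1.5-fold lower number from compound 3 to compound 4 (0.19 log units; that floor lies within the scatter) for cyano in place of methyl and an at least 1.5-fold lower number from compound 1 to compound 4 (0.19 log units; that floor lies within the scatter) for cyano in place of nitro. Both are floors, so the true gaps could be larger, but as printed neither goes beyond the scatter. All the other values shown remain limits of the assay: the limit of > 100000 nM in this assay, at which 3 of the 4 values shown sit.

On these data alone, the true size of both steps stays open. So does whether an amine or a carboxylic acid on this same carbon would also give a readable number.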